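The source may report more compounds than this note shows. Statements on the series, on what has been measured and on what is new or still open speak of the compounds shown alone.

Of the compounds shown here, three that share one core have been measured in an assay on HEK293 cells for inhibition of N-acylethanolamine-hydrolyzing acid amidase (Homo sapiens), read by fluorescence, with stated times of 10 min and 50 min; on this read-out higher numbers stand for weaker inhibition and lower numbers for stronger inhibition. Compound 1 `O=C(N[C@H]1CNC1=O)OCc1ccc(C2CCOCC2)cc1` gives 1370 nM. Compound 2 `O=C(N[C@H]1CNC1=O)OCc1ccc(OC2CCCCC2)cc1` gives 2070 nM, which is a 1.5-fold higher number from compound 1 to compound 2 (0.18 log units; within the scatter). Compound 3 `O=C(N[C@H]1CNC1=O)OCc1ccc(-c2cccnc2)cc1` gives 8110 nM, the highest of the three numbers and so the weakest inhibitor among them; the steps to it are a 5.9-fold higher number from compound 1 to compound 3 (0.77 log units; beyond the scatter) and a 3.9-fold higher number from compound 2 to compound 3 (0.59 log units; beyond the scatter). Compound 4 `O=C(N[C@H]1CNC1=O)OCc1ccc(-c2cocn2)cc1` has not yet been measured. It differs from compound 3 in one place: 1,3-oxazol-4-yl in place of pyridin-3-yl on an aromatic carbon. The two measured steps that bear on this change are the ones leading to compound 3, each swapping one group for another on the same aromatic carbon, and each modest and beyond the scatter. For the measured compounds named here, no measured compound shows what a five-membered aromatic ring does on that carbon, so the new group is taken to behave like the one it replaces. Compound 4 is therefore expected to give a number close to that of compound 3, with the step of a 1.2-fold lower number from compound 3 to compound 4 (0.06 log units; within the scatter) expected to stay within the scatter. The estimate for compound 4 is 7000 nM, with a range from 2500 nM to 20000 nM.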

Compound 4, half-maximal inhibitory concentration: 1880 nM
For compound 4 the middle estimate is 3.7-fold (0.57 log units) above the measured one, and the stated range ends above it.
By their numbers in this assay, from the lowest: compounds 1, 4 and 2 (each within the scatter of the next); then compound 3.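

On this aromatic carbon, para to a large group, exchanging one aromatic ring for another is not a neutral change: 1,3-oxazol-4-yl in place of pyridin-3-yl gives a 4.3-fold lower number from compound 3 to compound 4 (0.63 log units; beyond the scatter) in this assay. The five-membered ring also brings the number level with the two other groups, with a 1.1-fold lower number from compound 2 to compound 4 (0.04 log units; within the scatter) against cyclohexyloxy and a 1.4-fold higher number from compound 1 to compound 4 (0.14 log units; within the scatter) against oxan-4-yl, so among these four compounds only the pyridin-3-yl compound stands apart. Nothing available here gives a reason for this difference between the two rings.

Going by these compounds, what a plain phenyl ring or a pyridin-4-yl group would give on this carbon remains open. So does whether another five-membered ring, such as 1,3-thiazol-4-yl, would match 1,3-oxazol-4-yl.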